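Chloro in place of hydrogen on compound 3

The source may hold more compounds than are shown below. What is called first, only, known or untested is meant among the compounds shown, and "the series" means these compounds.

In an ADME assay (liver) for metabolic stability, with Liver microsome (Rattus norvegicus) as the target, read by LC-MS, using microsomes and NADPH, with stated times of 5 min and 60 min, tested at 4 uM (a higher number here means that more of the compound is left, a lower number that less of the compound is left), compound 3 `Cc1c(OCCCCOc2ccc(C(=O)O)cc2)ccc(C(=O)CC(C)C)c1O` gives 66%. Compound 2 `Cc1c(OCCCCOc2ccc(C(=O)O)cc2F)ccc(C(=O)CC(C)C)c1O` gives 57%, within the scatter of compound 3. Compound 1 `Cc1c(OCCCCOc2ccc(C(=O)O)cc2Cl)ccc(C(=O)CC2CCCC2)c1O` gives 21%, lower than compound 3 and beyond the scatter.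

The next step leads to compound 4 `Cc1c(OCCCCOc2ccc(C(=O)O)cc2Cl)ccc(C(=O)CC(C)C)c1O`: chloro in place of hydrogen on an aromatic carbon. This is chloro in place of hydrogen on an aromatic carbon, ortho to a large group and meta to a carboxy group.

The closest measured step is a number 9 percentage points higher from compound 2 to compound 3 (within the scatter), with hydrogen in place of fluoro on an aromatic carbon. Compound 1 also carries the chloro, but its carbonyl side chain differs from that of compound 3, so compound 1 with 21% cannot isolate the chloro change. Only a weak pointer to a lower number remains. The expected move in this assay is modest and close to the scatter, an estimated a number 11 percentage points lower from compound 3 to compound 4 (beyond the scatter). For compound 4 the estimated value is 55%, with an expected range of 38% to 68%.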

Compound 4, percent of the compound remaining: 61%
For compound 4 the middle estimate is 6 percentage points below the measured one; low and high end bracket the measured number.
By their numbers in this assay, from the lowest: compound 1; then compounds 2, 4 and 3 (each within the scatter of the next).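

In this assay chloro on this aromatic carbon, ortho to a large group and meta to a carboxy group, stays within the scatter of both hydrogen (a number 5 percentage points lower from compound 3 to compound 4 (within the scatter)) and fluoro (a number 4 percentage points higher from compound 2 to compound 4 (within the scatter)), so the three are not told apart with the isopropyl side chain. The large step lies on the saturated chain carbon bound to the carbonyl carbon (a number 40 percentage points higher from compound 1 to compound 4 (beyond the scatter)), which ties the low number of compound 1 to cyclopentyl in place of isopropyl, not to the chloro. Nothing measured here gives a reason for either result.

Open, from the compounds shown here alone, is whether a methoxy or a nitrile on this aromatic carbon would also stay within the scatter. Also open, going by these compounds, is how a cyclobutyl or a longer chain in place of isopropyl would read.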